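Chlorophenyl Propenone Amide: Expected Tolerance in Vero Cells

The compounds below may be only part of what the source reports. "The series", "measured", "known", "first", "only" and "open" are said of these compounds alone.

Compound 1 `COC(=O)c1cc(-c2cccc(NC(=O)c3ccc(OCc4ccc(Cl)cc4)cc3)c2)on1` was examined in an ADME assay on Vero cells (Chlorocebus sabaeus) for cytotoxicity, read by MTT assay, with a stated time of 72 h (a lower number here means that less compound is tolerated, a higher number that more compound is tolerated), where compound 1 gives only a limit, > 80 ug/mL. Compound 2 `COC(=O)c1cc(-c2cccc(NC(=O)c3ccc(/C=C/C(=O)c4ccc(CC(C)C)cc4)cc3)c2)on1` likewise gives only a limit in this assay, > 10 ug/mL. Compound 3 `COC(=O)c1cc(-c2cccc(NC(=O)c3ccc(/C=C/C(=O)c4ccc(F)cc4F)cc3)c2)on1` also gives only a limit, > 40 ug/mL. Compound 1 thus stands at the limit of > 80 ug/mL in this assay, at which 1 of the 3 values shown sits, and the two further values are limits as well. The change to compound 4 `COC(=O)c1cc(-c2cccc(NC(=O)c3ccc(/C=C/C(=O)c4ccc(Cl)cc4)cc3)c2)on1` is 2-((4-chlorophenyl)carbonyl)ethenyl in place of (4-chlorobenzyl)oxy on an aromatic carbon. The related steps a step that the two limits leave unreadable from compound 1 to compound 3 and a step that the two limits leave unreadable from compound 2 to compound 3 could not be sized, with a limit at each end, so no step beyond the scatter is expected in either direction. Compound 4 is expected to be tolerated at about 40 ug/mL, between 10 ug/mL and 100 ug/mL. The expected step is therefore an at least 2.0-fold lower number from compound 1 to compound 4 (0.30 log units; that floor lies within the scatter), within the scatter.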

Compound 4, half-maximal cytotoxic concentration: > 50 ug/mL
Compound 4: only a limit was reported; the forecaster's own chance of this, stated with the estimate: 70%; at least 1.2-fold (0.09 log units) between middle value and limit.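

In this assay, going by these compounds alone, compound 4 gives only a limit, as do compounds 1, 2 and 3, so no step between compounds 1, 2, 3 and 4 can be read. The compounds shown leave open whether these four differ in tolerance at all.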